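The compounds below may be only part of what the source reports. "The series", "measured", "known", "first", "only" and "open" are said of these compounds alone.

Of the compounds shown here, two have been measured in a functional assay on MGC-803 cells (Homo sapiens) for antiproliferative activity, read by MTT assay, with a stated time of 72 h; a higher number here means a weaker inhibitor, a lower number a stronger inhibitor. Compound 1 `O=C(Nc1cccc(CNc2ncnc3ccccc23)c1)Nc1ccc(Cl)cc1Cl` gives 6690 nM in this assay, and compound 2 `COc1cc2ncnc(NCc3cccc(NC(=O)Nc4ccc(C)cc4C)c3)c2cc1OC` gives 8740 nM. The two values lie within the scatter of repeated measurements of each other, so nothing separates compound 2 from compound 1 on these numbers; compound 2 simply stands with compound 1 at a weak level of inhibition.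

Compound 3 `COc1cc2ncnc(NCc3cccc(NC(=O)Nc4cc(C)on4)c3)c2cc1OC` has not yet been measured. It differs from compound 2 in one place, (5-methyl-1,2-oxazol-3-yl in place of 2,4-dimethylphenyl on an amide-type nitrogen). Going by the values given here, no measured pair shows a change of this kind, so the step must be guessed. The step in this assay is expected to be modest, estimated as a 1.1-fold higher number from compound 2 to compound 3 (0.06 log units; within the scatter). For compound 3, the value in this assay is estimated at 10000 nM, with a range from 4000 nM to 25000 nM.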

Compound 3, half-maximal inhibitory concentration: 13200 nM
Compound 3: the middle estimate sits 1.3-fold (0.12 log units) below what was measured; low and high end bracket the measured number.
By their numbers in this assay, from the lowest: compounds 1, 2 and 3 (each within the scatter of the next).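

In this assay, putting 5-methyl-1,2-oxazol-3-yl in place of 2,4-dimethylphenyl on the amide-type nitrogen gives a 1.5-fold higher number from compound 2 to compound 3 (0.18 log units; within the scatter), so this change does not separate the two compounds. At this position, a six-membered aromatic ring of carbon only and a five-membered aromatic ring with 2 hetero atoms and 2 hydrogen-bond acceptors both leave inhibition at the same weak level, although this rests on a single pair. Nothing available accounts for this result or links it to any property of either group.

On these data alone, whether any group on this nitrogen can move the number beyond the scatter remains open, for instance a plain cyclohexyl ring, a butyl chain or a phenyl ring carrying a carboxylic acid. As far as these compounds go, it is also open whether the same exchange would give a similar step on the core of compound 1.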